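Cinnamoyl in Place of Butyl on the Anilide Ring

This account rests on a few compounds, and the source may have more. Where it says the series, first, only, none or still open, it means among the compounds named here.

Compound 1, `COc1ccc(NC(=O)CSC(=S)N[C@H]2CCOC2=O)cc1`, gives only a limit in a functional assay on MCF7 cells (Homo sapiens) for cytotoxicity, read by MTT assay, with a stated time of 72 h; a higher number here means a weaker inhibitor, a lower number a stronger inhibitor: > 128000 nM.
Compound 2, `CCOC(=O)c1ccc(NC(=O)CSC(=S)N[C@H]2CCOC2=O)cc1`, gives 60300 nM in this assay.
Compound 3, `CCCCc1ccc(NC(=O)CSC(=S)N[C@H]2CCOC2=O)cc1`, gives 40200 nM in this assay.

All three share a core and differ only in the group on the aromatic carbon. Compound 3 has the lowest of the two numbers; its nearest neighbour is compound 2, and the gap a 1.5-fold lower number from compound 2 to compound 3 (0.18 log units; within the scatter) lies within the scatter. Against compound 1 only a limit is known (the limit of > 128000 nM in this assay, at which 1 of the 3 values shown sits), so the steps of an at least 2.1-fold lower number from compound 1 to compound 2 (0.32 log units; beyond the scatter) and an at least 3.1-fold lower number from compound 1 to compound 3 (0.50 log units; beyond the scatter) show at least a modest lowering.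

Compound 4, `O=C(CSC(=S)N[C@H]1CCOC1=O)Nc1ccc(C(=O)/C=C/c2ccccc2)cc1`, carries the change ((2-phenylethenyl)carbonyl in place of butyl on an aromatic carbon). For the measured compounds named here, the measured steps all concern the same position, but none involves a group of this size or kind; the only numbered comparison, from compound 2 to compound 3, stayed within the scatter. The evidence therefore points to a small shift at most. For compound 4 a step of a 2.0-fold lower number from compound 3 to compound 4 (0.30 log units; within the scatter) is expected, a modest lowering that might still fall within the scatter. Compound 4 is estimated at 20000 nM in this assay, with a range from 5000 nM to 80000 nM.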

Compound 4, half-maximal inhibitory concentration: 44300 nM
Estimate against measurement, compound 4: 2.2-fold (0.35 log units) below; the measured number falls inside the stated range.
By their numbers in this assay, from the lowest: compounds 3, 4 and 2 (each within the scatter of the next). At a limit, above all of these: compound 1.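

Compound 4 shows that this position takes a far larger group, (2-phenylethenyl)carbonyl with its own six-membered aromatic ring, and still gives a number in this assay that cannot be told apart from that of the butyl compound (a 1.1-fold higher number from compound 3 to compound 4 (0.04 log units; within the scatter)) or from that of the ethoxycarbonyl compound, where 2-phenylethenyl replaces ethoxy on the same carbonyl carbon (a 1.4-fold lower number from compound 2 to compound 4 (0.13 log units; within the scatter)). So neither the added size nor the added ring produces a change that can be read in this assay, while the step from the methoxy compound is again beyond the scatter (an at least 2.8-fold lower number from compound 1 to compound 4 (0.46 log units; beyond the scatter)). That last step is read against a limit, not a true number, for compound 1: the limit of > 128000 nM in this assay, at which 1 of the 4 values shown sits.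

On these data alone, it stays open what an amine, a carboxylic acid or a longer chain such as octyl at this position would do to the number in this assay. As far as these compounds go, it also stays open whether any group here can move the number beyond the scatter of compounds 2, 3 and 4, and whether methoxy stands alone in lying at a limit.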